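A few compounds are considered here, and "the series" means these few. Any claim that something is new, unique, unknown or untested is made for them only; others in the source may bear on it.

Measured so far:

Compound 1 `O=C(O)c1ccc(NC(=O)c2ccc(Oc3ccccc3)cc2)cc1`. In an assay on isolated protein for agonist activity at Bile acid receptor (Homo sapiens), read by TR-FRET, with a stated time of 3 h, in the absence of a further agent (on this read-out higher numbers stand for an effect only at larger amounts of compound and lower numbers for an effect already at smaller amounts), compound 1 gives > 10000 nM, a limit of the assay and not a number.
Compound 2 `COc1ccccc1C(=O)Nc1ccc(C)c(C(=O)O)c1`. In this assay compound 2 gives > 10000 nM, again a limit.
Compound 3 `CCCOc1cccc(C(=O)Nc2cccc(C(=O)O)c2)c1`. In this assay compound 3 gives 2150 nM.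

Going by the values given here, compound 3 thus holds the only numerical value in the set; the other two values sit at the limit of > 10000 nM in this assay, at which 2 of the 3 values shown sit. The next compound, compound 4 `O=C(O)c1cccc(NC(=O)c2cccc(OCC3CC3)c2)c1`, differs from compound 3 only by cyclopropyl in place of ethyl on a saturated chain carbon bound to an oxygen on an aromatic ring. Among the compounds with values here, no step between measured compounds bears on this exchange, so the expected change is small: a 1.3-fold lower number from compound 3 to compound 4 (0.13 log units; within the scatter), a step judged to lie within the usual scatter. Compound 4 is accordingly expected at 1600 nM, with a range from 500 nM to 5000 nM.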

Compound 4, half-maximal effective concentration: 1260 nM
Compound 4: the middle estimate sits 1.3-fold (0.10 log units) above what was measured, and the stated range covers the measured number.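

Cyclopropyl in place of ethyl on a saturated chain carbon bound to an oxygen on an aromatic ring gives a 1.7-fold lower number from compound 3 to compound 4 (0.23 log units; within the scatter) in this assay, the first exchange at this place with a value on both sides. At this place, the three-membered ring of carbon is thus accommodated with no change beyond the scatter. No measured property in the series accounts for this step.

As far as these compounds go, whether an amine, a carboxylic acid or a longer chain at this place would move the value beyond the scatter remains open. From the compounds shown here alone, whether the same exchange behaves alike on the core of compound 1 or compound 2 also remains open.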